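The source may hold more compounds than are shown below. What is called first, only, known or untested is meant among the compounds shown, and "the series" means these compounds.

In a functional assay on SK-MEL-5 cells (Homo sapiens) for inhibition, read by sulforhodamine B assay, with a stated time of 48 h, tested at 10 uM (on this read-out higher numbers stand for more inhibition of growth at the one concentration tested and lower numbers for less inhibition of growth), compound 1 (`COc1ccc(-c2nc3sc(-c4ccccc4)cn3n2)cc1`) gives 65%. That is the higher of the two numbers at hand: the other, from compound 2 (`COc1cc(-c2nc(N)n(CC(=O)Nc3ccc(/C(C)=N\O)cc3)n2)cc(OC)c1OC`), is 2.08%, a gap well beyond the scatter. Among the compounds with values here, these two compounds are not related by a change in one place, so nothing measured so far shows what a single substitution does here. Compound 3 (`COc1ccc(-c2nc3sc(-c4ccc(Cl)cc4)cn3n2)cc1`) keeps the core of compound 1 and differs from it at one point: chloro in place of hydrogen on an aromatic carbon, which turns phenyl into 4-chlorophenyl. Within the data shown here, with no measured step to lean on, only a small rise in inhibition of growth is expected, one that may well stay within the scatter. The expected step is a number 5 percentage points higher from compound 1 to compound 3 (within the scatter). For compound 3 the estimated value is 70%, with an expected range of 50% to 88%.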

Compound 3, percent growth inhibition at one concentration: 27.5%
Compound 3: middle estimate off by 42.5 percentage points, on the high side, outside the stated range (below it).
By their numbers in this assay, from the lowest: compound 2; then compound 3; then compound 1.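

Within the data shown here, the step gives the first comparison in one place in this assay: chloro in place of hydrogen on an aromatic carbon, para to a large group, turning phenyl into 4-chlorophenyl, comes with a number 37.5 percentage points lower from compound 1 to compound 3 (beyond the scatter). It shows that this position on the core of compound 1 is not indifferent to substitution, and that in this single case the added chloro goes with less inhibition of growth. Nothing at hand explains the drop.

The compounds shown leave open whether the loss belongs to chloro itself or would follow other groups at this place, such as fluoro, methyl or an amine. They also do not tell whether a chloro on another aromatic carbon of that ring would give a similar step.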